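Cytotoxicity notes on three measured compounds and one analogue

The source may report more compounds than this note shows. Statements on the series, on what has been measured and on what is new or still open speak of the compounds shown alone.

Measured so far:
compound 1 `Cc1noc(C)c1S(=O)(=O)N1CCC(N2CCC(C)CC2)CC1` — in an ADME assay on HCT-116 cells (Homo sapiens) for cytotoxicity, read by CellTiter-Glo, with a stated time of 72 h (a lower number here means a stronger inhibitor, a higher number a weaker inhibitor), compound 1 gives only a limit, > 10000 nM.
compound 2 `Cc1cc(C)c(S(=O)(=O)N2CCC(N3CCCCCC3)CC2)c(C)c1` — in this assay compound 2 gives only a limit, > 5000 nM.
compound 3 `CC1CCN(C2CCN(S(=O)(=O)c3ccccc3-c3ccc(Cl)cc3)CC2)CC1` — in this assay compound 3 gives only a limit, > 5000 nM.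

Compound 2 stands at a limit of this assay and not at a number; this is the limit of > 5000 nM in this assay, at which 2 of the 3 values shown sit. The remaining value sits at the limit of > 10000 nM in this assay, at which 1 of the 3 values shown sits. Among the measured compounds shown here, with every value a limit, no pair of compounds yields a measured step, and no size of change is known within the set.

The unmeasured compound 4 `Cc1cc(C)c(S(=O)(=O)N2CCC(N3CCCCC3)CC2)c(C)c1` differs from compound 2 in one place: piperidin-1-yl in place of azepan-1-yl on a saturated ring carbon. Since compound 2 shows only a limit, there is no number from which a measured direction could be read.

The expected step that the limit leaves unreadable from compound 2 to compound 4 is none beyond the scatter. Compound 4 is expected at 10000 nM, with a range from 4000 nM to 30000 nM, and most likely the assay again reports only a limit.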

Compound 4, half-maximal inhibitory concentration: > 5000 nM
Compound 4: a limit, no number (the forecaster's own chance of this, stated with the estimate: 80%); the middle value is on the limit's open side.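

Among the compounds shown here, compound 2 and compound 4 both stand only at limits in this assay, and no step between them can be read. The compounds shown leave open what number each would give in this assay, and whether piperidin-1-yl in place of azepan-1-yl changes it at all.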